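Ester branching on a shared core: isobutyl versus tert-butyl

The compounds below may be only part of what the source reports. "The series", "measured", "known", "first", "only" and "open" are said of these compounds alone.

Compound 1 `CC1=C(C(=O)OCC(C)C)C(c2cccs2)NC(=O)N1` carries an isobutyl ester; in an assay on membranes from HeLa cells for displacement of a labelled ligand from adenosine receptor A3 (Homo sapiens), read by scintillation counting, with a stated time of 180 min, tested at 1 uM (a lower number here means less inhibition, a higher number more inhibition at the concentration tested (going by the name of the read-out)), compound 1 gives 11%. Compound 2 `CC1=C(C(=O)OC(C)(C)C)C(c2cccs2)NC(=O)N1` differs by tert-butyl in place of isobutyl on an oxygen next to a carbonyl group, and in this assay compound 2 gives 7%, so that a number 4 percentage points lower from compound 1 to compound 2 (within the scatter). Compound 3 `CC1=C(C(=O)OCC(C)C)C(c2ccco2)NC(=S)N1` has a different core from compound 1; that difference between the two cores is not broken down here. In this assay compound 3 gives 10%, which lies within the scatter of both compound 1 and compound 2. Compound 4 `CC1=C(C(=O)OC(C)(C)C)C(c2ccco2)NC(=S)N1` is not yet measured and differs from compound 3 by tert-butyl in place of isobutyl on an oxygen next to a carbonyl group, the same change as from compound 1 to compound 2, at the same place. The step is expected to be a number 3 percentage points lower from compound 3 to compound 4 (within the scatter) because a number 4 percentage points lower from compound 1 to compound 2 (within the scatter). Compound 4 is therefore estimated at 7% in this assay, expected between 0% and 18%.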

Compound 4, a percentage reported as inhibition, at one concentration (the size of the read-out at that concentration, not a potency): 9%
Compound 4: the middle estimate sits 2 percentage points below what was measured; the measured number falls inside the stated range.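

Tert-butyl in place of isobutyl on an oxygen next to a carbonyl group gives a number 1 percentage points lower from compound 3 to compound 4 (within the scatter) in this assay. Set beside the earlier step, the change reads alike on both cores: the same change on two cores in this assay, a number 4 percentage points lower (within the scatter) from compound 1 to compound 2 and a number 1 percentage points lower (within the scatter) from compound 3 to compound 4, 3 percentage points apart, within the scatter of two such steps

Within the data shown here, this shows only that neither core gives a step beyond the scatter; with both steps this small, it does not show that a real effect of the change carries from one core to the other, and a single tested concentration says nothing about potency.

The compounds shown leave open whether a longer chain or a chain ending in an amine on that oxygen, or a carboxylic acid in place of the ester, would move the number beyond the scatter. The difference between the two cores also remains unresolved.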